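Acid for Morpholine Amide on Two Aryl Cores

This account rests on a few compounds, and the source may have more. Where it says the series, first, only, none or still open, it means among the compounds named here.

Compound 3 `O=C(/C=C/c1ccncc1-c1ccc2ccccc2c1)N1CCOCC1` is the only one of the three measured compounds to give a number in a functional assay on A549 cells (Homo sapiens) for inhibition, read by sulforhodamine B assay, with a stated time of 72 h; a higher number here means a weaker inhibitor of growth, a lower number a stronger inhibitor of growth: compound 3 gives 8410 nM. Compound 1 `O=C(O)/C=C/c1ccncc1-c1ccc2ccccc2c1` differs from compound 3 by hydroxy in place of morpholin-4-yl on a carbonyl carbon. In this assay compound 1 reaches only the limit of the assay, > 10000 nM. The step of an at least 1.1-fold higher number from compound 3 to compound 1 (0.07 log units; that floor lies within the scatter) is therefore known only as a floor, because of the limit of > 10000 nM in this assay, at which 2 of the 3 values shown sit. Compound 2 `O=C(/C=C/c1ccncc1-c1ccc2cc[nH]c2c1)N1CCOCC1` carries the morpholin-4-yl group on a second core; the difference between the two cores is not broken down here. In this assay compound 2 also gives the limit > 10000 nM. Compound 4 `O=C(O)/C=C/c1ccncc1-c1ccc2cc[nH]c2c1` is not yet measured; it differs from compound 2 by hydroxy in place of morpholin-4-yl on a carbonyl carbon, the same change as that from compound 3 to compound 1, made at the same place. For compound 4 the step that the limit leaves unreadable from compound 2 to compound 4 is expected to point the same way as the earlier one and to stay small, resting on an at least 1.1-fold higher number from compound 3 to compound 1 (0.07 log units; that floor lies within the scatter) having been read only as a floor. Compound 4 is thus estimated at 20000 nM in this assay, within 8000 nM to 60000 nM, and will most likely be reported only as a limit.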

Compound 4, concentration for 50% growth inhibition: > 10000 nM
Compound 4 was reported as a limit; the forecaster's own chance of this, stated with the estimate: 90%; the middle value does not contradict the limit.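

No new step can be read from compound 2 to compound 4 in this assay since both compounds stand at a limit and not at a number: (the limit of > 10000 nM in this assay, at which 3 of the 4 values shown sit). The compounds shown leave open how much hydroxy in place of morpholin-4-yl changes growth inhibition on either core, and whether the two cores differ at all.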